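Working notes: benzyl variation in a cytotoxicity series

The source may report more compounds than this note shows. Statements on the series, on what has been measured and on what is new or still open speak of the compounds shown alone.

Compound 1 `O=c1ccoc2cc(OCc3cn(Cc4ccc(Cl)cc4)nn3)ccc12` — in a functional assay on SGC-7901 cells (Homo sapiens) for cytotoxicity, read by MTT assay, with a stated time of 48 h (on this read-out higher numbers stand for weaker inhibition and lower numbers for stronger inhibition), compound 1 gives > 100000 nM, a limit.
Compound 2 `Cc1ccccc1Cn1cc(COc2ccc3c(=O)ccoc3c2)nn1` — in this assay compound 2 gives > 100000 nM, a limit.
Compound 3 `O=c1ccoc2cc(OCc3cn(Cc4cccc([N+](=O)[O-])c4)nn3)ccc12` — in this assay compound 3 gives > 100000 nM, a limit.

Compound 2 stands nowhere in particular among these numbers: its value in this assay is a limit and not a measurement, and the same holds for every other value shown (the limit of > 100000 nM in this assay, at which 3 of the 3 values shown sit). The measured steps are therefore unreadable: a step that the two limits leave unreadable from compound 1 to compound 2, a step that the two limits leave unreadable from compound 1 to compound 3 and a step that the two limits leave unreadable from compound 2 to compound 3 all join two limits, so neither size nor direction can be taken from them.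

Compound 4 `O=c1ccoc2cc(OCc3cn(Cc4ccc(Br)cc4)nn3)ccc12` is the next member. Against compound 2 the change is 4-bromophenyl in place of 2-methylphenyl on a saturated chain carbon bound to an aromatic nitrogen. Among the compounds with values here, no measured step bears a readable size on this change; what the three measured compounds show is that varying the benzyl group among 4-chlorobenzyl, 2-methylbenzyl and 3-nitrobenzyl left every value at the limit (the limit of > 100000 nM in this assay, at which 3 of the 3 values shown sit).

Compound 4 is accordingly expected to remain at the limit in this assay, because the limit of > 100000 nM in this assay, at which 3 of the 3 values shown sit, is where all measured members sit. The estimate for compound 4 is 150000 nM, with a range from 50000 nM to 500000 nM. The step from compound 2 to compound 4 is thus expected to be a step that the limit leaves unreadable from compound 2 to compound 4, none beyond the scatter.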

Compound 4, half-maximal inhibitory concentration: > 100000 nM
Compound 4: only a limit was reported (the forecaster's own chance of this, stated with the estimate: 85%); the middle value lies beyond the limit too.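

In this assay compound 4 gives > 100000 nM, a limit. The steps joining compound 4 to compound 1, compound 2 and compound 3 all link two limits, so none can be read for size or direction: the limit of > 100000 nM in this assay, at which 4 of the 4 values shown sit.

The compounds shown leave open whether any benzyl group on the shared core gives a value that is not a limit in this assay.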